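Cyclopropylamide in Place of Morpholine Amide on a Thiophene Scaffold

The compounds below may be only part of what the source reports. "The series", "measured", "known", "first", "only" and "open" are said of these compounds alone.

Of the compounds shown here, three sharing one core have been measured in a functional assay on A549 cells (Homo sapiens) for inhibition, read by sulforhodamine B assay, with a stated time of 72 h; on this read-out lower numbers stand for stronger inhibition and higher numbers for weaker inhibition. Compound 1 `Nc1sc(-c2ccc(Cl)cc2)c(-c2ccc(Cl)cc2)c1C(=O)N1CCCCC1` gives 4620 nM, compound 2 `CCOC(=O)Nc1sc(-c2ccc(Cl)cc2)c(-c2ccc(Cl)cc2)c1C(=O)NC1CC1` gives 39800 nM, and compound 3 `Nc1sc(-c2ccc(Cl)cc2)c(-c2ccc(Cl)cc2)c1C(=O)N1CCOCC1` gives 1870 nM. Compound 3 therefore stands lowest of the three, with compound 1 nearest and compound 2 furthest away. Within the data shown here, the one single-point step available, a 2.5-fold lower number from compound 1 to compound 3 (0.39 log units; beyond the scatter), shows that exchanging one six-membered cyclic amine for another on the carbonyl carbon shifts the read-out only modestly.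

Compound 4 `Nc1sc(-c2ccc(Cl)cc2)c(-c2ccc(Cl)cc2)c1C(=O)NC1CC1` is not yet measured. It differs from compound 3 by cyclopropylamino in place of morpholin-4-yl on a carbonyl carbon. Among the measured compounds shown here, no measured step covers this kind of exchange directly; the step from compound 1 to compound 3 stays within cyclic tertiary amides and only hints that the amide substituent matters to a modest degree. Compound 2 also carries cyclopropylamino on the carbonyl carbon but differs from compound 4 elsewhere too, so its high value can only be taken as a loose caution. On balance compound 4 is expected to give a higher number than compound 3, by a 3.2-fold higher number from compound 3 to compound 4 (0.51 log units; beyond the scatter). The estimate for compound 4 in this assay is 6000 nM, within a range from 1500 nM to 25000 nM.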

Compound 4, half-maximal inhibitory concentration: 1950 nM
Compound 4: middle estimate off by 3.1-fold (0.49 log units), on the high side; the measured number falls inside the stated range.
By their numbers in this assay, from the lowest: compounds 3 and 4 (each within the scatter of the next); then compound 1; then compound 2.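

In this assay the step of a 1.0-fold higher number from compound 3 to compound 4 (0.02 log units; within the scatter) shows that the amide position tolerates more than cyclic tertiary amides: cyclopropylamino, with its three-membered carbon ring and one hydrogen-bond donor, reads the same as morpholin-4-yl on a carbonyl carbon, and the step of a 2.4-fold lower number from compound 1 to compound 4 (0.37 log units; beyond the scatter) lies beyond the scatter, as the step from the piperidin-1-yl amide to the morpholine amide does. With cyclopropylamino held in place, the step of a 20-fold lower number from compound 2 to compound 4 (1.31 log units; beyond the scatter) isolates the change on a nitrogen on an aromatic ring, so the high number of compound 2 goes with ethoxycarbonyl there and not with the cyclopropylamino group on the carbonyl carbon. No evidence is at hand to explain either result.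

The compounds shown leave open whether an open-chain group such as dimethylamino or a larger ring such as cyclohexylamino on the carbonyl carbon would also read like compound 3 and compound 4. They also leave open whether a smaller group than ethoxycarbonyl on that nitrogen, such as acetyl, would carry the same large penalty.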